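The source may hold more compounds than are shown below. What is called first, only, known or untested is meant among the compounds shown, and "the series" means these compounds.

Compound 1 `CC(=O)Nc1ccc(O)c(C(=O)/C=C/c2ccccc2)c1`: 85500 nM
Compound 2 `CC(=O)Nc1ccc(O)c(C(=O)/C=C/c2cccc(F)c2)c1`: 78600 nM

These two values come from an ADME assay on THP-1 cells (Homo sapiens) for cytotoxicity, read by flow cytometry and propidium iodide staining, with a stated time of 72 h; a lower number here means a stronger inhibitor, a higher number a weaker inhibitor. Compound 2, at 78600 nM, stands within the scatter of compound 1, so the pair sets a single level and gives no order. Compound 3 `CC(=O)Nc1ccc(O)c(C(=O)/C=C/c2cccc(C(F)(F)F)c2)c1` has not yet been measured. It differs from compound 2 by trifluoromethyl in place of fluoro on an aromatic carbon. Among the measured compounds shown here, only one measured step bears on this change: a 1.1-fold lower number from compound 1 to compound 2 (0.04 log units; within the scatter), where fluoro took the place of hydrogen on an aromatic carbon, and that step lies within the scatter. For the measured compounds named here, no measured compound yet carries trifluoromethyl, so the evidence is thin. A shift beyond the scatter in this assay is not expected in either direction. The expected step is a 1.1-fold lower number from compound 2 to compound 3 (0.05 log units; within the scatter). For compound 3 the estimated value is 70000 nM, with an expected range of 35000 nM to 130000 nM.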

Compound 3, half-maximal inhibitory concentration: 8400 nM
For compound 3 the middle estimate is 8.3-fold (0.92 log units) above the measured one; measured number below the stated range.
By their numbers in this assay, from the lowest: compound 3; then compounds 2 and 1 (each within the scatter of the next).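

In this assay, this place on the aromatic ring turns out to respond to the group it carries: trifluoromethyl in place of fluoro gives a 9.4-fold lower number from compound 2 to compound 3 (0.97 log units; beyond the scatter), and trifluoromethyl in place of hydrogen gives a 10-fold lower number from compound 1 to compound 3 (1.01 log units; beyond the scatter). Compound 1 and compound 2 lie within the scatter of each other, so fluoro alone had given no sign that the position could move the number, and compound 3 now stands apart from both. Nothing in the data shown accounts for this step.

The compounds shown cannot tell whether the step belongs to trifluoromethyl alone or would also come with chlorine, a methyl, a methoxy or a nitrile at this place. They also leave open whether trifluoromethyl would give the same step on another carbon of this ring.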